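Swapping the para substituent: from pentyl to fluoro

The source may report more compounds than this note shows. Statements on the series, on what has been measured and on what is new or still open speak of the compounds shown alone.

Measured so far, in a functional assay on FTC-133 cells (Homo sapiens) for cytotoxicity, read by MTT assay, with a stated time of 24 h; a lower number here means a stronger inhibitor, a higher number a weaker inhibitor:
compound 1 `CN1O[C@@H](n2cc(-c3ccccc3)nn2)C[C@@H]1CO` gives 6030 nM;
compound 2 `COc1ccc(-c2cn([C@H]3C[C@H](CO)N(C)O3)nn2)cc1` gives 7000 nM;
compound 3 `CCCCCc1ccc(-c2cn([C@H]3C[C@H](CO)N(C)O3)nn2)cc1` gives 3950 nM.

Compound 3 gives the lowest of the three numbers, yet its steps to compounds 1 and 2 both sit within the scatter: a 1.5-fold lower number from compound 1 to compound 3 (0.18 log units; within the scatter) and a 1.8-fold lower number from compound 2 to compound 3 (0.25 log units; within the scatter). Compound 4 `CN1O[C@@H](n2cc(-c3ccc(F)cc3)nn2)C[C@@H]1CO` differs from compound 3 by fluoro in place of pentyl on an aromatic carbon. Among the measured compounds shown here, the steps that bear on this change all replace the same aromatic hydrogen, methoxy or pentyl and all stayed within the scatter, including a 1.2-fold higher number from compound 1 to compound 2 (0.06 log units; within the scatter). No step beyond the scatter is therefore expected in this assay. Compound 4 is estimated at 6000 nM (range 3000 nM to 12000 nM), which would mean an expected 1.5-fold higher number from compound 3 to compound 4 (0.18 log units; within the scatter).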

Compound 4, half-maximal inhibitory concentration: 6070 nM
The estimate for compound 4 lay 1.0-fold (0.01 log units) below the measured number; measured number inside the range.
By their numbers in this assay, from the lowest: compounds 3, 1, 4 and 2 (each within the scatter of the next).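

In this assay fluoro joins hydrogen, methoxy and pentyl on this aromatic carbon, and all its steps stay within the scatter (a 1.5-fold higher number from compound 3 to compound 4 (0.19 log units; within the scatter)) (a 1.2-fold lower number from compound 2 to compound 4 (0.06 log units; within the scatter)) (a 1.0-fold higher number from compound 1 to compound 4 (0.00 log units; within the scatter)). A lone fluorine and a pentyl chain therefore read alike here, so across these four compounds this position shows no clear response to the group it carries. No measurement at hand explains this flat result.

From the compounds shown here alone, whether an amine or a carboxylic acid on this carbon would give a step beyond the scatter remains open. So does whether any change elsewhere on the shared core would.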